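The source may report more compounds than this note shows. Statements on the series, on what has been measured and on what is new or still open speak of the compounds shown alone.

Compound 2, `CC1(c2ccccc2)CC(S(=O)(=O)c2ccc(F)cc2)=C(c2ccc(/C(N)=N\O)cc2)O1`, stands highest of the three numbers in an ADME assay on HepG2 cells (Homo sapiens) for cytotoxicity, read by MTT assay, with a stated time of 72 h; on this read-out lower numbers stand for higher toxicity in this test and higher numbers for lower toxicity in this test. Compound 2 gives 68300 nM. Compound 1, `CC1(c2ccc(-c3cccc(/C(N)=N\O)c3)cc2)CC(S(=O)(=O)c2ccc(F)cc2)=C(c2ccc(/C(N)=N\O)cc2)O1`, gives 19000 nM, and compound 3, `N/C(=N/O)c1ccc(C2=C(S(=O)(=O)c3ccc(F)cc3)CC(c3ccccc3)(c3ccccc3)O2)cc1`, gives 19200 nM in this assay. Both neighbours lie beyond the scatter below compound 2: a 3.6-fold higher number from compound 1 to compound 2 (0.56 log units; beyond the scatter), and a 3.6-fold lower number from compound 2 to compound 3 (0.55 log units; beyond the scatter).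

Compound 4, `CC1(c2ccc(-c3ccncc3)cc2)CC(S(=O)(=O)c2ccc(F)cc2)=C(c2ccc(/C(N)=N\O)cc2)O1`, differs from compound 2 at the place where compound 1 carries its larger group: pyridin-4-yl in place of hydrogen on an aromatic carbon. Among the compounds with values here, two measured steps bear on this. The step from compound 1 to compound 2 shows that removing an aromatic ring from this aromatic carbon raised the number, so adding pyridin-4-yl there would be expected to lower it again. The step from compound 2 to compound 3 shows that adding a phenyl elsewhere in the core also lowered the number by a modest amount. The entering group is smaller than the group of compound 1, so the step is expected to be modest and downward: a 2.7-fold lower number from compound 2 to compound 4 (0.44 log units; beyond the scatter). Compound 4 is therefore estimated at 25000 nM, within a range of 10000 nM to 60000 nM in this assay.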

Compound 4, half-maximal cytotoxic concentration: 30300 nM
Compound 4: middle estimate off by 1.2-fold (0.08 log units), on the low side; measured number inside the range.
By their numbers in this assay, from the lowest: compounds 1, 3 and 4 (each within the scatter of the next); then compound 2.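

In this assay, the step of a 2.3-fold lower number from compound 2 to compound 4 (0.35 log units; beyond the scatter) shows that a single pyridin-4-yl ring on this aromatic carbon is enough to lower the number, which compound 1, with its larger group, could not show by itself. The step of a 1.6-fold higher number from compound 1 to compound 4 (0.20 log units; within the scatter) lies within the scatter, so this test does not tell pyridin-4-yl from the larger group at this position, and the extra atoms of compound 1 add no measurable change. Nothing in the available data explains these steps.

The compounds shown leave open whether an amine, a carboxylic acid or a plain phenyl on this aromatic carbon would give a number like that of compound 4. They also leave open whether the ring nitrogen of pyridin-4-yl matters here at all.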